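Swapping the aryl amide ring in a tetrazole series

The source may hold more compounds than are shown below. What is called first, only, known or untested is meant among the compounds shown, and "the series" means these compounds.

Compound 1 `CCCCCCCCCCCCn1nnc(C(NC(=O)c2ccc(C)cc2)c2ccccc2)n1` is the starting point. In an assay on microsomes from liver for inhibition of sterol O-acyltransferase 1 (Rattus norvegicus) (a higher number here means a weaker inhibitor, a lower number a stronger inhibitor), compound 1 gives 510 nM. Compound 2 `CCCCCCCCCCCCn1nnc(C(NC(=O)c2ccc([N+](=O)[O-])cc2)c2ccccc2)n1` carries a nitro in place of the methyl on the same ring; in this assay compound 2 gives 540 nM. The step of a 1.1-fold higher number from compound 1 to compound 2 (0.02 log units; within the scatter) shows that these two numbers lie within the scatter of each other, so compound 2 stands level with compound 1 and neither can be called the weaker of the pair.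

Compound 3 `CCCCCCCCCCCCn1nnc(C(NC(=O)c2ccnc(SC)c2)c2ccccc2)n1` goes further: it brings (a group of 8 heavy atoms (6 carbon, 1 nitrogen, 1 sulfur; one six-membered aromatic ring with 1 hetero atom) in place of a group of 9 heavy atoms (6 carbon, 1 nitrogen, 2 oxygen; one six-membered aromatic ring of carbon only), on a carbonyl carbon). Among the compounds with values here, the only measured step, from compound 1 to compound 2, changed a single substituent on the ring and stayed within the scatter; no measured step replaces the ring itself, so it offers little guidance for a swap of this kind. With nothing pointing to a large move in either direction, the expected step of a 1.1-fold higher number from compound 2 to compound 3 (0.05 log units; within the scatter) is small. Compound 3 is therefore estimated to give 600 nM in this assay, with a range from 250 nM to 1500 nM.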

Compound 3, half-maximal inhibitory concentration: 80 nM
For compound 3 the middle estimate is 7.5-fold (0.88 log units) above the measured one, and the stated range ends above it.
By their numbers in this assay, from the lowest: compound 3; then compounds 1 and 2 (each within the scatter of the next).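

Up to this point, the only change on this ring, nitro in place of methyl, had left the number in this assay within the scatter, so the position on the carbonyl carbon could have seemed insensitive to what it carries. Replacing the carbon-only ring with an aromatic ring holding one hetero atom and a sulfur-bearing group gives a real gain, and it appears against both earlier compounds (a 6.8-fold lower number from compound 2 to compound 3 (0.83 log units; beyond the scatter)) (a 6.4-fold lower number from compound 1 to compound 3 (0.80 log units; beyond the scatter)), so what sits on this carbonyl carbon can matter for this enzyme even though the first substituent swap showed nothing. No measurement here explains why this replacement gives a stronger inhibitor.

The ring hetero atom and the sulfur-bearing group arrive together in compound 3, so these compounds cannot say which of them carries the gain, or whether both are needed. A ring with the hetero atom alone, a carbon-only phenyl ring with the same sulfur group, or a methoxy or an amine in place of that sulfur group would begin to separate the two.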